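Compound 3 to compound 4: a change on the carbonyl carbon

This account rests on a few compounds, and the source may have more. Where it says the series, first, only, none or still open, it means among the compounds named here.

In a functional assay with Oryctolagus cuniculus as the target (on this read-out lower numbers stand for stronger inhibition and higher numbers for weaker inhibition), compound 1 `COc1ccc(-c2nc(/N=C(\N)N3CCOCC3)sc2-c2ccc(OC)cc2)cc1` is reported only as a limit, < 1000 nM. Compound 2 `COc1ccc(-c2nc(CNC(C)=O)sc2-c2ccc(OC)cc2)cc1` gives 15 nM. Compound 3 `COc1ccc(-c2nc(CNC(=O)c3cccnc3)sc2-c2ccc(OC)cc2)cc1` gives 25 nM. For the measured compounds named here, these are the only two numbers, and they lie within the scatter of each other. The steps from compound 1 have no readable size.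

The next structure is compound 4 `COc1ccc(-c2nc(CNC(=O)C3=NNC(=O)CC3)sc2-c2ccc(OC)cc2)cc1`, and the change from compound 3 is a group of 7 heavy atoms (4 carbon, 2 nitrogen, 1 oxygen; one six-membered non-aromatic ring with 2 hetero atoms) in place of a group of 6 heavy atoms (5 carbon, 1 nitrogen; one six-membered aromatic ring with 1 hetero atom), on a carbonyl carbon. Going by the values given here, the leaving pyridin-3-yl is aromatic, the entering ring non-aromatic, and no measured compound carries that entering group.

Among the compounds with values here, the one measured step at this carbonyl carbon, a 1.7-fold higher number from compound 2 to compound 3 (0.22 log units; within the scatter), stayed within the scatter, so no clear change in either direction is expected in this assay. A single step is thin support, so the expected range is kept wide. The expected size is a 1.2-fold higher number from compound 3 to compound 4 (0.08 log units; within the scatter). For compound 4 the estimate is 30 nM, with an expected range from 10 nM to 100 nM.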

Compound 4, half-maximal inhibitory concentration: 55 nM
The estimate for compound 4 lay 1.8-fold (0.26 log units) below the measured number, within the range that was stated.
By their numbers in this assay, from the lowest: compounds 2 and 3 (each within the scatter of the next); then compound 4.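

In this assay, this carbonyl carbon now gives its first steps beyond the scatter, both modest: a 2.2-fold higher number from compound 3 to compound 4 (0.34 log units; beyond the scatter) and a 3.7-fold higher number from compound 2 to compound 4 (0.56 log units; beyond the scatter). Methyl and pyridin-3-yl had not separated here, so the group on this carbon can shift the read-out, and the non-aromatic ring with 2 hetero atoms is the only group shown to do so, in the direction of weaker inhibition. No measured information shown bears on the cause of this shift.

With one such ring, the compounds shown do not separate the loss of the aromatic ring from the added ring nitrogen and the ring carbonyl. Also open, on these data alone, is how phenyl, a carboxylic acid, an amine or a longer alkyl chain on this carbonyl carbon would read out.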